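Swapping the Azole on a Fused Bicyclic Core

This account rests on a few compounds, and the source may have more. Where it says the series, first, only, none or still open, it means among the compounds named here.

Within the data shown here, compound 1 `CCc1c(SC)nc2nc(-c3noc(C)n3)cn2c1C` is one of two compounds measured in a functional assay on the whole organism with Rattus norvegicus as the target; a higher number here means that more compound is needed for the effect, a lower number that less compound is needed. Here compound 1 gives 2 mg/kg, the lower of the two numbers, while compound 2 `C=CCc1c(OC)nc2nc(-c3nnc(C)o3)cn2c1C` gives 10 mg/kg, and the gap between the two lies beyond the usual scatter. Compound 3 `CCc1c(SC)nc2nc(-c3nc(C)cs3)cn2c1C` has not yet been measured in this assay. It differs from compound 1 in one place: 4-methyl-1,3-thiazol-2-yl in place of 5-methyl-1,2,4-oxadiazol-3-yl on an aromatic carbon. Among the measured compounds shown here, no measured pair shows a step of this kind, so the expected change from compound 1 to compound 3 is small, a 1.5-fold higher number from compound 1 to compound 3 (0.18 log units; within the scatter), with no direction beyond the scatter. Compound 3 is therefore estimated at 3 mg/kg, within a range of 1 mg/kg to 10 mg/kg.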

Compound 3, minimum effective dose: > 50 mg/kg
Compound 3 gave a limit, no number; the forecaster's own chance of this, stated with the estimate: 5%; middle value at least 16-fold (1.22 log units) from the limit.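

In this assay compound 3 stands at a limit of the assay, not at a number: the limit of > 50 mg/kg in this assay, at which 1 of the 3 values shown sits.

Among these compounds, putting 4-methyl-1,3-thiazol-2-yl in place of 5-methyl-1,2,4-oxadiazol-3-yl gives an at least 25-fold higher number from compound 1 to compound 3 (1.39 log units; beyond the scatter), the first step in this set that changes one place only. It shows that the outcome at this aromatic carbon depends strongly on which five-membered ring is attached, even with the heavy-atom count unchanged.

The two rings differ in their hetero atoms in several ways at once, and the compounds shown do not separate these differences. Going by these compounds, how a carboxylic acid or an amine on this carbon would read in this assay also remains open.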